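Swapping Sulfamoyl for Acetamido on a Urea-Linked Phenyl

The source may hold more compounds than are shown below. What is called first, only, known or untested is meant among the compounds shown, and "the series" means these compounds.

Of the compounds shown here, three sharing one core have been tested in a functional assay on MDA-MB-231 cells (Homo sapiens) for antiproliferative activity, read by MTT assay, with a stated time of 72 h; on this read-out lower numbers stand for stronger inhibition and higher numbers for weaker inhibition. Compound 1 `O=C(Nc1ccc(-c2noc(-c3cccc(NS(=O)(=O)c4ccc(C(F)(F)F)cc4)c3)n2)c(Cl)c1)c1cccnc1` sits at a limit of the assay, giving > 10000 nM, so no number is known for it. Compound 2 `CC(=O)Nc1ccc(S(=O)(=O)Nc2cccc(-c3nc(-c4ccc(NC(=O)c5cccnc5)cc4)no3)c2)cc1` gives a measured value in this assay of 5200 nM. Compound 3 `NS(=O)(=O)c1ccc(NC(=O)Nc2cccc(-c3nc(-c4ccc(NC(=O)c5cccnc5)cc4Cl)no3)c2)cc1` also sits at a limit of the assay, giving > 10000 nM, which is not a number. Compound 3 thus stands where two of the three values shown sit, namely (the limit of > 10000 nM in this assay, at which 2 of the 3 values shown sit), and it cannot be placed against compound 2 by more than the statement that compound 2 returned a number while compound 3 did not.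

Compound 4 `CC(=O)Nc1ccc(NC(=O)Nc2cccc(-c3nc(-c4ccc(NC(=O)c5cccnc5)cc4Cl)no3)c2)cc1` is the next compound to be measured in this assay. It differs from compound 3 in one place: acetamido in place of sulfamoyl on an aromatic carbon. Among the measured compounds shown here, no step between measured compounds isolates such an exchange, so there is no directly comparable precedent among the three values shown. Given that compound 3 returns only a limit, the step from compound 3 to compound 4 is expected to be small, with compound 4 estimated to stay near the limit rather than move clearly beyond the scatter, as expressed in a number no higher from compound 3 to compound 4 (the limit leaves the size open). Compound 4 is estimated to give about 10000 nM in this assay, within a range from 3000 nM to 30000 nM.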

Compound 4, half-maximal inhibitory concentration: > 10000 nM
Compound 4: a limit, no number (the forecaster's own chance of this, stated with the estimate: 55%); the middle value sits exactly at the limit.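

Among the compounds shown here, compound 3 and compound 4 each return a limit and not a number, so the exchange of sulfamoyl for acetamido between them gives no step that can be read: the limit of > 10000 nM in this assay, at which 3 of the 4 values shown sit. The compounds shown leave open how acetamido and sulfamoyl compare at this place, and what number either compound would give.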